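Amide variation on the dihydrobenzofuran series

A few compounds are considered here, and "the series" means these few. Any claim that something is new, unique, unknown or untested is made for them only; others in the source may bear on it.

Two compounds carry numbers in an assay on NIH3T3 cells for binding affinity to melatonin receptor type 1B (Homo sapiens); a lower number here means a stronger inhibitor, a higher number a weaker inhibitor. Compound 1 `CC(C)C(=O)NCCCc1cccc2c1C[C@@H](CCCCc1ccccc1)O2` gives 40 nM in this assay. Compound 2 `O=C(NC[C@@H]1C[C@H]1c1cccc2c1C[C@@H](CCCCc1ccccc1)O2)C1CC1` gives 5 nM in this assay, the lower of the two numbers; compound 1 sits at a higher number, and the gap between them lies beyond the usual scatter. The two compounds differ in more than one place, so no single change can be read from their values.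

Compound 3 `CC(C)C(=O)NC[C@@H]1C[C@H]1c1cccc2c1C[C@@H](CCCCc1ccccc1)O2` is the next member. Relative to compound 2 the change is isopropyl in place of cyclopropyl on a carbonyl carbon, cyclopropylcarbonyl to isopropylcarbonyl, with the rest of the molecule kept. The swap exchanges groups of equal heavy-atom count, so only a small step is expected, if any, and possibly a slight rise in the number. The step of a 1.6-fold higher number from compound 2 to compound 3 (0.20 log units; within the scatter) is the expected outcome. For compound 3 the estimate in this assay is 8 nM, between 3 nM and 20 nM.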

Compound 3, inhibition constant: 90 nM
Compound 3: middle estimate off by 11-fold (1.05 log units), on the low side; the whole stated range lies below it.
By their numbers in this assay, from the lowest: compound 2; then compound 1; then compound 3.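

In this assay the group on this carbonyl carbon is not interchangeable: cyclopropylcarbonyl to isopropylcarbonyl gives an 18-fold higher number from compound 2 to compound 3 (1.26 log units; beyond the scatter) even though the heavy-atom count stays the same and neither group has hydrogen-bond donors, acceptors or a net charge. By the computed comparison, the three-membered ring is what leaves in this one pair. The earlier pair could not give this reading. Those compounds differ in more than one place. No available measurement accounts for the size of this step.

Cyclobutyl, ethyl or methyl on the same carbonyl carbon would show whether the three-membered ring itself matters or whether other groups can match cyclopropyl. On these data alone, it also remains open whether cyclopropyl in place of isopropyl on the carbonyl carbon of compound 1 would give a step of similar size.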